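The compounds below may be only part of what the source reports. "The series", "measured", "known", "first", "only" and "open" are said of these compounds alone.

Measured in a functional assay on MCF7 cells (Homo sapiens) for cytotoxicity, read by MTT assay, with a stated time of 72 h; on this read-out higher numbers stand for weaker inhibition of growth and lower numbers for stronger inhibition of growth:
compound 1 `COc1ccc(CNc2nc([Se]C)nc3ccccc23)cc1`: 98600 nM
compound 2 `Sc1nc(NCc2ccccc2)c2ccccc2n1`: a limit, > 100000 nM
compound 3 `[SeH]c1nc(NCc2ccccc2)c2ccccc2n1`: a limit, > 100000 nM

Compound 3 stands at the limit of this assay. Compound 2 also sits at that limit (the limit of > 100000 nM in this assay, at which 2 of the 3 values shown sit). The step from compound 2 to compound 3 is a step that the two limits leave unreadable from compound 2 to compound 3.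

Compound 4 `C[Se]c1nc(NCc2ccccc2)c2ccccc2n1` differs from compound 3 by methyl in place of hydrogen on a selenium. Going by the values given here, no measured step covers this change directly. Compound 1 carries the same methyl on selenium and in this assay gives 98600 nM. Compound 4 is therefore expected to show a step of a number no higher from compound 3 to compound 4 (the limit leaves the size open), none beyond the scatter, and to come out near 100000 nM, estimated between 40000 nM and 250000 nM.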

Compound 4, concentration for total growth inhibition: 67000 nM
The estimate for compound 4 lay 1.5-fold (0.17 log units) above the measured number; low and high end bracket the measured number.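

In this assay compound 4 gives a readable number where compound 2 and compound 3 give only a limit: the limit of > 100000 nM in this assay, at which 2 of the 4 values shown sit. Methyl in place of hydrogen on a selenium gives an at least 1.4-fold lower number from compound 3 to compound 4 (0.17 log units; that floor lies within the scatter), and the group of 2 heavy atoms in place of one sulfur atom gives an at least 1.4-fold lower number from compound 2 to compound 4 (0.17 log units; that floor lies within the scatter). Hydrogen in place of methoxy on an aromatic carbon gives a 1.5-fold lower number from compound 1 to compound 4 (0.17 log units; within the scatter), so that methoxy makes no difference beyond the scatter here.

Open, from the compounds shown here alone, is whether a longer chain on the selenium, such as ethyl, or a chain ending in an amine or a carboxylic acid, would move the number beyond the scatter.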